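Growth inhibition notes: tert-butyl replaced by chloro

The source may hold more compounds than are shown below. What is called first, only, known or untested is meant among the compounds shown, and "the series" means these compounds.

Measured in a functional assay on SMMC-7721 cells (Homo sapiens) for inhibition, read by CCK-8 assay, with a stated time of 72 h, tested at 8 uM; a lower number here means less inhibition of growth, a higher number more inhibition of growth at the concentration tested:
Compound 1 `Cc1ccc(SCc2ccc(C(=O)Nc3ccccc3N)cc2)cc1`: 82.7%
Compound 2 `Nc1ccccc1NC(=O)c1ccc(CSc2ccc(Br)cc2)cc1`: 25.3%
Compound 3 `CC(C)(C)c1ccc(SCc2ccc(C(=O)Nc3ccccc3N)cc2)cc1`: 46.1%

Compound 3 is second highest of the three values in this assay. Compound 4 `Nc1ccccc1NC(=O)c1ccc(CSc2ccc(Cl)cc2)cc1` differs from it as follows: chloro in place of tert-butyl on an aromatic carbon. The measured steps that bear on this are large, a number 57.4 percentage points lower from compound 1 to compound 2 (beyond the scatter) and a number 36.6 percentage points lower from compound 1 to compound 3 (beyond the scatter), and modest, a number 20.8 percentage points higher from compound 2 to compound 3 (beyond the scatter). The closest comparison is compound 2, which also carries a halogen there, at 25.3%. A modest fall is therefore expected, with an estimated change of a number 13.1 percentage points lower from compound 3 to compound 4 (beyond the scatter). Three compounds establish no firm trend, so the range stays wide. The estimate for compound 4 is 33%, with an expected range of 15% to 60%.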

Compound 4, percent growth inhibition at one concentration: 16.5%
For compound 4 the middle estimate is 16.5 percentage points above the measured one; the range from low to high includes it.
By their numbers in this assay, from the lowest: compounds 4 and 2 (each within the scatter of the next); then compound 3; then compound 1.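

In this assay, exchanging bromo for chloro at this position gives a number 8.8 percentage points lower from compound 2 to compound 4 (within the scatter), so the two halogens cannot be told apart here. The change from tert-butyl to chloro gives a number 29.6 percentage points lower from compound 3 to compound 4 (beyond the scatter) and that from methyl to chloro gives a number 66.2 percentage points lower from compound 1 to compound 4 (beyond the scatter), which places both halogen compounds below both alkyl compounds. No supporting measurement bears on why these substituents differ. As far as these compounds go, whether an amine, a methoxy group or an ethyl group at this position would stay near compound 1 or fall towards compound 4 remains open.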